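This account rests on a few compounds, and the source may have more. Where it says the series, first, only, none or still open, it means among the compounds named here.

Compound 1, `Nc1scc(CN2CCN(c3ccccc3F)CC2)c1C(=O)c1ccc(Cl)cc1`, was tested in an assay on CHO cells for displacement of a labelled ligand from adenosine receptor A3 (Homo sapiens), read by scintillation counting, with a stated time of 120 min, tested at 10 uM (on this read-out higher numbers stand for more inhibition at the one concentration tested (going by the name of the read-out) and lower numbers for less inhibition), where compound 1 gives 0%. Compound 2, `Nc1scc(CN2CCN(c3ccc(F)c(Cl)c3)CC2)c1C(=O)c1ccc(Cl)cc1`, carries a 3-chloro-4-fluorophenyl in place of the 2-fluorophenyl on an amine nitrogen in a ring; in this assay compound 2 gives 0%. The step of no change at the digits printed from compound 1 to compound 2 (within the scatter) shows that exchanging one halogen-bearing aryl group for another on that ring nitrogen left the read-out where it was. On the numbers shown, compound 2 therefore stands level with compound 1, with nothing to separate the two.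

Compound 3, `Nc1scc(CN2CCN(c3c(Cl)cccc3Cl)CC2)c1C(=O)c1ccc(Cl)cc1`, is the next member of the series, and it differs from compound 2 as follows: 2,6-dichlorophenyl in place of 3-chloro-4-fluorophenyl on an amine nitrogen in a ring. Going by the values given here, the only measured step that bears on this kind of change is the one between the two measured compounds, which was flat within the scatter, and it gives no hint that a third halogen pattern on the same aryl group would behave differently. The expectation is therefore a step of no change at the digits printed from compound 2 to compound 3 (within the scatter) that stays within the scatter. Compound 3 is expected to give 0% in this assay, between -10% and 15%.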

Compound 3, a percentage reported as inhibition, at one concentration (the size of the read-out at that concentration, not a potency): 1%
Estimate against measurement, compound 3: 1 percentage points below; the measured number falls inside the stated range.
By their numbers in this assay, from the lowest: compounds 1, 2 and 3 (each within the scatter of the next).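

With 2,6-dichlorophenyl in place of 3-chloro-4-fluorophenyl on the amine nitrogen in the ring, this assay gives a number 1 percentage points higher from compound 2 to compound 3 (within the scatter), and with the same group in place of 2-fluorophenyl it gives a number 1 percentage points higher from compound 1 to compound 3 (within the scatter). This adds a third halogen pattern to the two already seen: 2-fluorophenyl, 3-chloro-4-fluorophenyl and 2,6-dichlorophenyl all sit at this position with values that cannot be told apart, so among these three groups the choice of halogens and their places on the phenyl ring makes no measurable difference to this read-out. No independent measurement is available that could explain this flat result.

On these data alone, all three compounds carry a halogen-bearing phenyl group at this position and all read close to zero, so it remains open whether a group of another kind on the same nitrogen, such as a methoxyphenyl, a hydroxyphenyl or a benzyl group, would give a different number. As far as these compounds go, it also remains open whether changes elsewhere on the shared core would move the read-out at all.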